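The source may report more compounds than this note shows. Statements on the series, on what has been measured and on what is new or still open speak of the compounds shown alone.

Of the compounds shown here, three have so far been measured in a functional assay on MT2 cells (Homo sapiens) for cytotoxicity, read by MTT assay; on this read-out lower numbers stand for higher toxicity in this test and higher numbers for lower toxicity in this test. Compound 1 `CC(C)=CCOc1cc(Nc2nccs2)ccc1Cl` gives 26000 nM, the highest of the three numbers. Compound 2 `CCCc1ccc(Nc2nccs2)cc1OCC=C(C)C` gives 23000 nM, and the step of a 1.1-fold lower number from compound 1 to compound 2 (0.05 log units; within the scatter) leaves the two within the scatter of each other. For the measured compounds named here, compound 3 `CC1=C(COc2cc(Nc3nccs3)ccc2Cl)CCC1` gives 11000 nM, and the step of a 2.4-fold lower number from compound 1 to compound 3 (0.37 log units; beyond the scatter) is the only measured change that reaches beyond the scatter.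

Compound 4 `CC(C)=CCOc1cc(Nc2nccc(N)n2)ccc1Cl` has not yet been measured. It differs from compound 1 in a single place: 4-aminopyrimidin-2-yl in place of 1,3-thiazol-2-yl on a nitrogen on an aromatic ring. Neither measured step touches this part of the molecule; both change the other side of the shared core, so nothing measured bears directly on this replacement. Going by the values given here, the only guidance is that the two changes made elsewhere moved the number modestly or not at all. For compound 4 the expected step from its parent is no change at the digits printed from compound 1 to compound 4 (within the scatter), a change that stays within the scatter. Compound 4 is estimated at 26000 nM, with a range from 10000 nM to 65000 nM.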

Compound 4, half-maximal cytotoxic concentration: 500 nM
For compound 4 the middle estimate is 52-fold (1.72 log units) above the measured one; the whole stated range lies above it.
By their numbers in this assay, from the lowest: compound 4; then compound 3; then compounds 2 and 1 (each within the scatter of the next).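

In this assay, the group on the nitrogen on an aromatic ring proves to be the most sensitive place changed so far: 4-aminopyrimidin-2-yl in place of 1,3-thiazol-2-yl gives a 52-fold lower number from compound 1 to compound 4 (1.72 log units; beyond the scatter), well beyond the scatter and far larger than a 2.4-fold lower number from compound 1 to compound 3 (0.37 log units; beyond the scatter). This single replacement alters several things at once, including ring size, the hetero atoms and the added hydrogen-bond donor, so the higher toxicity in this test cannot be assigned to any one of them. No available evidence accounts for the size of this step.

The compounds shown leave open whether the amino group matters or the ring alone is enough, a question that a plain pyrimidin-2-yl or a methyl in place of the amine could address. They also leave open whether the step would keep its size with propyl in place of chloro.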